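The source may report more compounds than this note shows. Statements on the series, on what has been measured and on what is new or still open speak of the compounds shown alone.

Three related compounds have been tested in a functional assay on Bel-7402 cells (Homo sapiens) for antiproliferative activity, read by MTT assay, with a stated time of 72 h; on this read-out higher numbers stand for weaker inhibition and lower numbers for stronger inhibition. Compound 1, `Cc1ccccc1NC1=C/C(=N/NC(N)=S)C(=O)N=C1Nc1ccccc1C`, gives 1710 nM. Compound 2, `NC(=S)N/N=C1/C=C(Nc2ccc(Cl)cc2)C(Nc2ccc(Cl)cc2)=NC1=O`, gives 820 nM, a lower number that lies beyond the usual scatter of the measurement. Compound 3, `NC(=S)N/N=C1/C=C(Nc2cccc([N+](=O)[O-])c2)C(Nc2cccc([N+](=O)[O-])c2)=NC1=O`, gives 8110 nM, a higher number, also beyond the scatter. On these three numbers compound 1 stands second highest, so it inhibits growth less strongly than compound 2 and more strongly than compound 3.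

Compound 4, `Cc1ccccc1NC1=C/C(=N/N=C(\N)SCc2ccccc2)C(=O)N=C1Nc1ccccc1C`, has not yet been measured. It differs from compound 1 in one place: a group of 11 heavy atoms (8 carbon, 2 nitrogen, 1 sulfur; one six-membered aromatic ring of carbon only) in place of a group of 4 heavy atoms (1 carbon, 2 nitrogen, 1 sulfur; no ring), on a double-bonded nitrogen. The core is kept, and the side group on the double-bonded nitrogen is enlarged.

Going by the values given here, no pair of measured compounds differs in just this way, so nothing measured shows what such an enlargement does here. The change is large in size but leaves the rest of the molecule untouched, and the three measured compounds span only a modest range. The step expected in this assay is a 1.7-fold lower number from compound 1 to compound 4 (0.23 log units; within the scatter), a small move toward stronger inhibition that could equally fall within the scatter. Compound 4 is therefore estimated to give about 1000 nM, with a likely range from 300 nM to 4000 nM.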

Compound 4, half-maximal inhibitory concentration: 17100 nM
Estimate against measurement, compound 4: 17-fold (1.23 log units) below; the measured number lies above the stated range.
By their numbers in this assay, from the lowest: compound 2; then compound 1; then compound 3; then compound 4.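

In this assay, the side group on the double-bonded nitrogen turns out to matter: the enlargement gives a 10-fold higher number from compound 1 to compound 4 (1.00 log units; beyond the scatter), a clear move toward weaker inhibition. Compounds 1, 2 and 3 all carry the same group of 4 heavy atoms at this place and differ only in their other aromatic rings, so they could not show this sensitivity. The entering group differs from the leaving one at once in size, in its six-membered aromatic ring and in its counts of hydrogen-bond donors and acceptors; which of these differences matters cannot be told from this single step, and no measurement at hand explains the loss.

From the compounds shown here alone, it remains open whether a smaller version of the entering group, for instance one with a methyl group in place of the aromatic ring, would stay close to compound 1 or lose as much as compound 4. Also open, going by these compounds, is whether the same replacement made on compound 2 or compound 3 would give a step of similar size, or whether a side group ending in an amine or a carboxylic acid would be tolerated here.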